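A Side-Chain Swap on an Amide That Showed No Activity

The compounds below may be only part of what the source reports. "The series", "measured", "known", "first", "only" and "open" are said of these compounds alone.

Of the compounds shown here, three have been tested in an assay on HEK293 cells for agonist activity at transient receptor potential cation channel subfamily M member 8 (Homo sapiens), read by fluorescence and calcium flux, with a stated time of 15 min; a lower number here means that less compound is needed, a higher number that more compound is needed for the effect. Compound 1 `Cc1ccc(OCC(=O)N(Cc2cccs2)c2cccnc2)cc1` gives 198 nM in this assay, and compound 2 `CCN(Cc1cccs1)C(=O)c1cc2cc(C)ccc2o1` gives 120 nM in this assay. Compound 3 `CCN(C(=O)COc1ccc(C)cc1)C(C)c1cccs1` is recorded as "not active" (no number reported) in this assay, so no number stands for it at all; it therefore sits apart from compound 1 and compound 2, both of which gave a measurable half-maximal effective concentration. Compound 3 shares its aryloxy-acetamide part with compound 1, and the two differ only in what sits on the amide-type nitrogen.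

Compound 4 `CCN(Cc1cncs1)C(=O)COc1ccc(C)cc1` differs from compound 3 in a single place: (1,3-thiazol-5-yl)methyl in place of 1-(thiophen-2-yl)ethyl on an amide-type nitrogen. Among the measured compounds shown here, no measured step between these two exists, so what follows is an expectation only. Since compound 3 produced no number, any measurable result for compound 4 would amount to a step toward lower numbers in this assay, and a step beyond the usual scatter. Such a step is expected here, with compound 1 at 198 nM showing that an amide of this core can be active. Compound 4 is expected to give about 400 nM in this assay, with a range from 80 nM to 4000 nM.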

Compound 4, half-maximal effective concentration: 1100 nM
The estimate for compound 4 lay 2.8-fold (0.44 log units) below the measured number, within the range that was stated.
By their numbers in this assay, from the lowest: compounds 2 and 1 (each within the scatter of the next); then compound 4.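

Among the compounds shown here, compound 3 is recorded as not active in this assay, with no number, while compound 4 gives 1100 nM, so no step between these two compounds can be read. Nothing available explains this difference. The compounds shown leave open which part of the change from 1-(thiophen-2-yl)ethyl to (1,3-thiazol-5-yl)methyl goes with the measurable activity of compound 4.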